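The source may report more compounds than this note shows. Statements on the series, on what has been measured and on what is new or still open speak of the compounds shown alone.

Three measured compounds frame the question. Compound 1 `CCN(Cc1ccccc1)C(=O)C1CCN(S(=O)(=O)c2ccc3[nH]ncc3c2)CC1` reaches 86% in a functional assay on CHO cells for positive allosteric modulation of muscarinic acetylcholine receptor M5 (Homo sapiens), read by calcium flux; a lower number here means a smaller maximal response, a higher number a larger maximal response. Compound 2 `CCN(C(=O)C1CCN(S(=O)(=O)c2ccc(OC)cc2)CC1)[C@H](C)c1ccccc1` reaches 90% in this assay, and compound 3 `CCN(C(=O)C1CCN(S(=O)(=O)c2ccc3cn[nH]c3c2)CC1)[C@H](C)c1ccccc1` reaches 87% in this assay. Within the data shown here, the only single-point step among them, a number 3 percentage points lower from compound 2 to compound 3 (within the scatter), accompanies the exchange of 4-methoxyphenyl for 1H-indazol-6-yl on the sulfonyl sulfur. Compound 3 therefore sits within the scatter of both neighbours: its number is close to that of compound 1 and close to that of compound 2, so none of the three can be told apart from the others on these numbers.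

Compound 4 `CCN(C(=O)C1CCN(S(=O)(=O)c2ccc3[nH]ncc3c2)CC1)[C@H](C)c1ccccc1` is the compound that has not yet been measured. It differs from compound 3 in one place: 1H-indazol-5-yl in place of 1H-indazol-6-yl on a sulfonyl sulfur. Among the measured compounds shown here, no measured step bears directly on this exchange, and the one related step, from compound 2 to compound 3, stayed within the scatter. Compound 1 carries the same 1H-indazol-5-yl group on the sulfonyl sulfur, though with a different amide substituent, and its value of 86% lies within the scatter of compound 3. On this basis compound 4 is expected to show no change at the digits printed from compound 3 to compound 4 (within the scatter) in this assay, that is, no step beyond the scatter. The estimate for compound 4 is therefore 87%, with a likely range from 78% to 96%.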

Compound 4, largest response reached (reported as percent of maximum), in percent of the reference or control that the assay uses: 86%
Estimate against measurement, compound 4: 1 percentage points above; the measured number falls inside the stated range.
By their numbers in this assay, from the lowest: compounds 1, 4, 3 and 2 (each within the scatter of the next).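

In this assay, 1H-indazol-5-yl in place of 1H-indazol-6-yl on the sulfonyl sulfur gives a number 1 percentage points lower from compound 3 to compound 4 (within the scatter) and so adds a direct reading at this position: the two groups, which match in every count computed for them, cannot be told apart here. Set against 4-methoxyphenyl at the same place, 1H-indazol-5-yl gives a number 4 percentage points lower from compound 2 to compound 4 (within the scatter) in this exchange, which matches what the earlier step to 1H-indazol-6-yl showed, while methyl in place of hydrogen on the saturated chain carbon bound to the amide-type nitrogen and an aromatic carbon, a change no earlier pair isolated, gives no change at the digits printed from compound 1 to compound 4 (within the scatter) and thus no detectable effect on the response. No available information explains these results.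

The compounds shown leave open whether a quite different group on the sulfonyl sulfur, such as 4-aminophenyl or 4-carboxyphenyl, would move the maximal response beyond the scatter. On these data alone, it also remains open whether a longer chain, such as ethyl in place of that methyl, or a carboxylic acid on the amide substituent would change the response.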